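Removing 1-hydroxyethyl from compound 2

A few compounds are considered here, and "the series" means these few. Any claim that something is new, unique, unknown or untested is made for them only; others in the source may bear on it.

In an ADME assay on L1210 cells (Mus musculus) for cytotoxicity, with a stated time of 48 h (a lower number here means a stronger inhibitor, a higher number a weaker inhibitor), compound 2 (`C=C1[C@H](C)CCC[C@]1(C)CC/C(C)=C/CC1=C(O)C(=O)C=C(N[C@H](C(=O)O)[C@@H](C)O)C1=O`) reads > 10 ug/mL, which is a limit. Compound 1 (`CC1=CCC[C@](C)(CC/C(C)=C/CC2=C(O)C(=O)C=C(N[C@H](C(=O)O)[C@@H](C)O)C2=O)[C@@H]1C`) reads > 10 ug/mL, also a limit. Between these two there is a step that the two limits leave unreadable from compound 1 to compound 2. Compound 4 (`C=C1[C@H](C)CCC[C@]1(C)CC/C(C)=C/CC1=C(O)C(=O)C=C(NCC(=O)O)C1=O`) differs from compound 2 by hydrogen in place of 1-hydroxyethyl on a saturated chain carbon bound to an amine nitrogen and a carbonyl carbon. The same difference reads 1-carboxy-2-hydroxypropyl to carboxymethyl. One readable step changes this group: compound 3 (`CC1=CCC[C@](C)(CC/C(C)=C/CC2=C(O)C(=O)C=C(N[C@@H](C(=O)O)C(C)C)C2=O)[C@@H]1C`) reads 3 ug/mL, and the step is an at least 3.3-fold lower number from compound 1 to compound 3 (0.52 log units; beyond the scatter). It ends in 1-carboxy-2-methylpropyl rather than carboxymethyl, so it transfers only loosely. On the evidence of compound 3 at 3 ug/mL, a modest drop is expected. Compound 4 may also stay at the limit. The expected change is an at least 1.4-fold lower number from compound 2 to compound 4 (0.15 log units; that floor lies within the scatter). The estimate for compound 4 is 7 ug/mL, with an expected range of 2.5 ug/mL to 20 ug/mL.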

Compound 4, half-maximal inhibitory concentration: 4 ug/mL
Beside the measured number, compound 4's estimate is 1.8-fold (0.24 log units) above it, and the stated range covers the measured number.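

In this assay, hydrogen in place of 1-hydroxyethyl gives an at least 2.5-fold lower number from compound 2 to compound 4 (0.39 log units; beyond the scatter). The 1-hydroxyethyl group is therefore not needed for a reading inside the assay range, and both readable steps at this carbon, on two different cores, remove the hydroxyl and lower the number. The size of this step is only a floor, as its starting point is a limit: the limit of > 10 ug/mL in this assay, at which 2 of the 4 values shown sit.

From the compounds shown here alone, whether a benzyl group on this carbon, or an amide in place of the carboxylic acid, would lower the number further remains open. Also open, going by these compounds, is whether the same change carries over to the core of compound 1.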